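A few compounds are considered here, and "the series" means these few. Any claim that something is new, unique, unknown or untested is made for them only; others in the source may bear on it.

Of the compounds shown here, two sharing one core have been measured in a functional assay on ovarian cells (Homo sapiens) for antiproliferative activity; on this read-out lower numbers stand for stronger inhibition of growth and higher numbers for weaker inhibition of growth. Compound 1 `N=C(N)N/N=C/c1c(-c2ccccn2)nc2sc(Cl)cn12`, which carries pyridin-2-yl, gives 7080 nM, and compound 2 `N=C(N)N/N=C/c1c(-c2cccnc2)nc2sc(Cl)cn12`, which carries pyridin-3-yl, gives 15500 nM. That is the higher of the two numbers, so compound 2 stands as the weaker growth inhibitor of this pair. For the measured compounds named here, the next structure, compound 3 `N=C(N)N/N=C/c1c(-c2ccncc2)nc2sc(Cl)cn12`, alters only one group: pyridin-4-yl in place of pyridin-3-yl on an aromatic carbon. In plain terms, pyridin-4-yl stands in place of pyridin-3-yl on an aromatic carbon. Going by the values given here, only one measured step bears on this change, the exchange of pyridin-2-yl for pyridin-3-yl at the same place: a 2.2-fold higher number from compound 1 to compound 2 (0.34 log units; beyond the scatter). That step is modest, and a single step gives no trend, so the data cannot show whether pyridin-4-yl would extend it or reverse it. In this assay no firm direction is therefore expected, and most likely no step beyond the scatter. The estimated step is a 1.3-fold lower number from compound 2 to compound 3 (0.11 log units; within the scatter). For compound 3 the expected value is 12000 nM, with an estimated range from 5500 nM to 27000 nM.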

Compound 3, concentration for 50% growth inhibition: 10200 nM
Estimate against measurement, compound 3: 1.2-fold (0.07 log units) above; low and high end bracket the measured number.
By their numbers in this assay, from the lowest: compounds 1, 3 and 2 (each within the scatter of the next, the first and the last beyond it).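

In this assay, the third pyridinyl group at this aromatic carbon gives a 1.5-fold lower number from compound 2 to compound 3 (0.18 log units; within the scatter) and, set against pyridin-2-yl, a 1.4-fold higher number from compound 1 to compound 3 (0.16 log units; within the scatter) so compound 3 cannot be told apart from either of the other two compounds. The earlier step, a 2.2-fold higher number from compound 1 to compound 2 (0.34 log units; beyond the scatter) remains the only one of the three beyond the scatter, and it now appears as a modest gap between the two ends of a closely spaced set rather than the start of a trend, since pyridin-4-yl neither extends that step nor clearly reverses it. Nothing available offers a reason for these small differences among pyridin-2-yl, pyridin-3-yl and pyridin-4-yl.

The compounds shown leave open whether this position tolerates only pyridinyl groups or whether a plain phenyl ring, with no ring nitrogen, would give a similar number. They also leave open whether an amine or a carboxylic acid placed on the pyridinyl ring, or a saturated ring such as piperidine in its place, would produce a step clearly beyond the scatter.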